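Swapping a nitrophenyl arm for a thiophene in a sulfonamide series

The source may hold more compounds than are shown below. What is called first, only, known or untested is meant among the compounds shown, and "the series" means these compounds.

Of the compounds shown here, three sharing one core have been measured in a functional assay on NCI-H460 cells (Homo sapiens) for inhibition, with a stated time of 72 h; a higher number here means a weaker inhibitor, a lower number a stronger inhibitor. Compound 1 `COc1ccc(S(=O)(=O)N2CCc3cccc(-c4ccc(N)cc4)c32)cc1` gives 288 nM. Compound 2 `COc1ccc(S(=O)(=O)N2CCc3cccc(-c4ccc(F)nc4)c32)cc1` gives 135 nM, and compound 3 `COc1ccc(S(=O)(=O)N2CCc3cccc(-c4ccc([N+](=O)[O-])cc4)c32)cc1` gives 53.1 nM, the lowest of the three numbers. Both steps leading to compound 3 lowered the number: a 5.4-fold lower number from compound 1 to compound 3 (0.73 log units; beyond the scatter) and a 2.5-fold lower number from compound 2 to compound 3 (0.41 log units; beyond the scatter). The step of a 2.1-fold lower number from compound 1 to compound 2 (0.33 log units; beyond the scatter) shows the same order between the two weaker compounds.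

Compound 4 `COc1ccc(S(=O)(=O)N2CCc3cccc(-c4cccs4)c32)cc1` has not yet been measured. It differs from compound 3 in one place: thiophen-2-yl in place of 4-nitrophenyl on an aromatic carbon. Among the compounds with values here, no measured step swaps in a thiophen-2-yl group, so the comparison leans on the finding that every arm other than 4-nitrophenyl gave a higher number in this assay, as in the step of a 2.5-fold lower number from compound 2 to compound 3 (0.41 log units; beyond the scatter). Removing the nitro-bearing ring is therefore expected to raise the number by a modest amount, though likely less than the full step seen from compound 1. For compound 4 the estimated value in this assay is 150 nM, with a range from 60 nM to 400 nM, which means an expected step of a 2.8-fold higher number from compound 3 to compound 4 (0.45 log units; beyond the scatter).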

Compound 4, half-maximal inhibitory concentration: 229 nM
Compound 4: the middle estimate sits 1.5-fold (0.18 log units) below what was measured; measured number inside the range.
By their numbers in this assay, from the lowest: compound 3; then compounds 2, 4 and 1 (each within the scatter of the next, the first and the last beyond it).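

At this aromatic carbon, putting thiophen-2-yl in place of 4-nitrophenyl gives a 4.3-fold higher number from compound 3 to compound 4 (0.63 log units; beyond the scatter) in this assay, so this five-membered ring does not keep the low number of compound 3. Thiophen-2-yl cannot be ranked against the other two arms, since a 1.7-fold higher number from compound 2 to compound 4 (0.23 log units; within the scatter) and a 1.3-fold lower number from compound 1 to compound 4 (0.10 log units; within the scatter) both lie within the scatter, even though compound 1 and compound 2 are separated beyond it. Nothing available explains why the thiophen-2-yl arm gives a higher number than the 4-nitrophenyl arm.

On these data alone, it remains open whether the low number of compound 3 comes from the nitro group or from the six-membered ring carrying it. A plain phenyl ring, a nitrile on the phenyl ring, or a nitro group on the thiophene could help separate the two.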